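An amide in place of diethylamino on compound 2

The source may report more compounds than this note shows. Statements on the series, on what has been measured and on what is new or still open speak of the compounds shown alone.

Among the measured compounds shown here, in an ADME assay for permeability, using PAMPA (on this read-out higher numbers stand for higher permeability and lower numbers for lower permeability), compound 1 (`COc1cc(N2CCC(CC(=O)N3CCOCC3)CC2)ccc1Nc1nc(NC2CCCCC2)c2nc[nH]c2n1`) gives 409 10^-6 cm/s and compound 2 (`CCN(CC)CC1CCN(c2ccc(Nc3nc(NC4CCCCC4)c4nc[nH]c4n3)c(OC)c2)CC1`) gives 480 10^-6 cm/s as the other of the two numbers so far, and these lie within the scatter of each other. Compound 3 (`COc1cc(N2CCC(CC(=O)N3CCCC3)CC2)ccc1Nc1nc(NC2CCCCC2)c2nc[nH]c2n1`) is still unmeasured and carries (pyrrolidin-1-yl)carbonyl in place of diethylamino on a saturated chain carbon bound to a saturated ring carbon. For the measured compounds named here, one measured step bears on this change: a 1.2-fold higher number from compound 1 to compound 2 (0.07 log units; within the scatter) with diethylamino in place of (morpholin-4-yl)carbonyl on that same carbon. Going by the values given here, no measured compound yet carries (pyrrolidin-1-yl)carbonyl, so this single step is a thin guide. On that basis the expected result is a 1.1-fold lower number from compound 2 to compound 3 (0.04 log units; within the scatter) and so nothing beyond the scatter in this assay for this change. Compound 3 is expected to read 440 10^-6 cm/s with an estimated range from 230 10^-6 cm/s to 800 10^-6 cm/s on this measurement.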

Compound 3, apparent permeability: 1690 10^-6 cm/s
Estimate against measurement, compound 3: 3.8-fold (0.58 log units) below, and the stated range ends below it.
By their numbers in this assay, from the lowest: compounds 1 and 2 (each within the scatter of the next); then compound 3.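

In this assay this position, a saturated chain carbon bound to a saturated ring carbon, proves able to move the read-out beyond the scatter: (pyrrolidin-1-yl)carbonyl in place of diethylamino gives a 3.5-fold higher number from compound 2 to compound 3 (0.55 log units; beyond the scatter), whereas compound 1 and compound 2 had stayed within the scatter of each other. The carbonyl alone does not go with the higher number, since compound 1 carries one too, and pyrrolidin-1-yl in place of morpholin-4-yl on that carbonyl carbon gives a 4.1-fold higher number from compound 1 to compound 3 (0.62 log units; beyond the scatter), so the group on the carbonyl carbon matters here. Nothing at hand gives a reason for these steps.

The compounds shown leave open whether the higher number follows the five-membered ring itself or only the lack of the morpholine oxygen. Piperidin-1-yl on the same carbonyl carbon would help to separate these two readings.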